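The source may hold more compounds than are shown below. What is called first, only, known or untested is meant among the compounds shown, and "the series" means these compounds.

Measured so far in a functional assay on HCT-116 cells (Homo sapiens) for antiproliferative activity, read by CCK-8 assay, with a stated time of 72 h, tested at 8 uM; a lower number here means a weaker effect, a higher number a stronger effect of the compound at the concentration tested:

Compound 1, `CC(C)n1cnc2c(Nc3cccc(Cl)c3)nc(NCOCc3ccc(C(=O)Nc4ccccc4N)cc3)nc21`: 63.4%
Compound 2, `CC(C)n1cnc2c(Nc3cccc(Cl)c3)nc(NCOCc3ccc(/C=C/C(=O)Nc4ccccc4N)cc3)nc21`: 27.9%
Compound 3, `CCCCn1cnc2c(Nc3ccccc3)nc(NCOCc3ccc(/C=C/C(=O)Nc4ccccc4N)cc3)nc21`: 51.9%

Compound 4, `CCCCn1cnc2c(Nc3ccccc3)nc(NCOCc3ccc(C(=O)Nc4ccccc4N)cc3)nc21`, has not yet been measured in this assay.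

Compound 1 and compound 2 share one core and differ in a single place. The change from compound 2 to compound 1 is this:

(2-aminophenyl)carbamoyl in place of 2-((2-aminophenyl)carbamoyl)ethenyl on an aromatic carbon

In this assay that change made a step of a number 35.5 percentage points higher from compound 2 to compound 1 (beyond the scatter).

Compound 3 and compound 4 share a second core. The difference between the two cores, that of compound 2 and that of compound 3, is not broken down here. On this second core the same change is made, from compound 3 to compound 4:

(2-aminophenyl)carbamoyl in place of 2-((2-aminophenyl)carbamoyl)ethenyl on an aromatic carbon

The two "place" descriptions agree word for word, so this is the same change, made on a different core. Because the earlier step was a number 35.5 percentage points higher from compound 2 to compound 1 (beyond the scatter), a rise is expected here too. Compound 3 already stands well above compound 2 in this assay, and the read-out cannot go beyond full inhibition, so the expected step from compound 3 to compound 4 is somewhat smaller than the earlier one: about a number 26.1 percentage points higher from compound 3 to compound 4 (beyond the scatter). On that basis compound 4 is estimated to give 78% in this assay, most likely between 60% and 95%.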

Compound 4, a percentage reported as inhibition, at one concentration (the size of the read-out at that concentration, not a potency): 74.9%
Compound 4: middle estimate off by 3.1 percentage points, on the high side; low and high end bracket the measured number.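

In this assay, putting (2-aminophenyl)carbamoyl in place of 2-((2-aminophenyl)carbamoyl)ethenyl gave a step of a number 23 percentage points higher from compound 3 to compound 4 (beyond the scatter), so the read-out rose on this second core as it had on the first. Set side by side, the two steps point the same way and cannot be told apart in size: the same change on two cores in this assay, a number 35.5 percentage points higher (beyond the scatter) from compound 2 to compound 1 and a number 23 percentage points higher (beyond the scatter) from compound 3 to compound 4, 12.5 percentage points apart, within the scatter of two such steps. This shows that, for these two pairs, the change carried over from one core to the other, but two pairs cannot establish a rule for other cores, and the data do not explain why the read-out rises or give a potency, since each number comes from a single concentration.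

As far as these compounds go, the two cores differ from each other in more than one place, so the separate contributions of the isopropyl and butyl chains and of the chlorine on the aniline ring remain open. Also open, from the compounds shown here alone, is how the series would respond to a longer chain joining the aromatic ring to the carbonyl, or to a hydroxamic acid in place of the 2-aminophenyl amide.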